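A few compounds are considered here, and "the series" means these few. Any claim that something is new, unique, unknown or untested is made for them only; others in the source may bear on it.

Working notes on the series. In an ADME assay on MT4 cells (Homo sapiens) for cytotoxicity, read by MTT assay, with a stated time of 96 h (a lower number here means that less compound is tolerated, a higher number that more compound is tolerated), compound 2, `NS(=O)(=O)c1ccc(N2N=C(c3ccccc3)CC2c2ccccc2F)cc1`, gives 42000 nM. Compound 1, `NS(=O)(=O)c1ccc(N2N=C(c3ccc(Oc4ccccc4)cc3)CC2c2ccccc2F)cc1`, gives 36000 nM in this assay, and compound 3, `NS(=O)(=O)c1ccc(N2N=C(c3ccc(OCc4ccccc4)cc3)CC2c2ccccc2F)cc1`, gives 39000 nM. The three numbers sit together: a 1.2-fold higher number from compound 1 to compound 2 (0.07 log units; within the scatter), a 1.1-fold higher number from compound 1 to compound 3 (0.03 log units; within the scatter) and a 1.1-fold lower number from compound 2 to compound 3 (0.03 log units; within the scatter) are each within the scatter, so on the numbers shown compound 2 stands level with the other two, and nothing measured so far has moved this read-out.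

Compound 4, `NS(=O)(=O)c1ccc(N2N=C(c3ccccc3)CC2c2ccccc2Cl)cc1`, differs from compound 2 as follows: chloro in place of fluoro on an aromatic carbon. Going by the values given here, none of the measured steps touches this position; the steps at hand concern phenoxy, benzyloxy and hydrogen on the other aromatic ring of the shared core, and all of them stayed flat. There is therefore no measured basis for a shift in this assay, and the change is small in what it counts, so the expectation is a step no larger than the scatter, with no direction preferred: for compound 4 the estimated step is no change at the digits printed from compound 2 to compound 4 (within the scatter).

Compound 4 is thus expected to give about 42000 nM in this assay, with a range from 25000 nM to 70000 nM.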

Compound 4, half-maximal cytotoxic concentration: 44000 nM
The estimate for compound 4 lay 1.0-fold (0.02 log units) below the measured number, and the stated range covers the measured number.
By their numbers in this assay, from the lowest: compounds 1, 3, 2 and 4 (each within the scatter of the next).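

Going by these compounds alone, the earlier compounds changed only the other aromatic ring of the shared core, while compound 4 gives the first reading at the halogen site, on the ring carbon ortho to a large group. In this assay, the exchange of 2-fluorophenyl for 2-chlorophenyl gives a 1.0-fold higher number from compound 2 to compound 4 (0.02 log units; within the scatter) and therefore does not separate chloro from fluoro here. The flat picture seen for phenoxy, benzyloxy and hydrogen on the other ring now extends to this one halogen exchange, with compound 1, compound 2, compound 3 and compound 4 all sitting together and none going against it, though no accompanying measurement bears on this result.

Still open, as far as these compounds go, is whether this position stays flat for groups unlike the two halogens, such as an amine, a carboxylic acid or a longer chain in place of chloro. From the compounds shown here alone, it is equally open whether an amine or a carboxylic acid on the other aromatic ring would shift this read-out away from the level shared by the four compounds.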